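Swapping Fluoro for Methyl at the Assay Ceiling

This account rests on a few compounds, and the source may have more. Where it says the series, first, only, none or still open, it means among the compounds named here.

This study measures how strongly a set of related compounds hold back the growth of breast cancer cells, using a functional assay on MCF7 cells (Homo sapiens) for cytotoxicity, read by MTT assay, with a stated time of 4 days; on this read-out higher numbers stand for weaker inhibition and lower numbers for stronger inhibition. Compound 3, with the structure `Cc1ccc(S(=O)(=O)Oc2ccc3c(c2C)[C@H](Cn2cc(-c4ccc(F)cc4)nn2)[C@@]24CC(=O)[C@@](C)(CC[C@@H]32)C4)cc1`, gives in this assay > 20000 nM, which is a limit of the assay rather than a measured number. Compound 1, with the structure `Cc1ccc(S(=O)(=O)Oc2ccc3c(c2C)[C@H](Cn2cc(-c4ccc(Br)cc4)nn2)[C@@]24CC(=O)[C@@](C)(CC[C@@H]32)C4)cc1`, gives > 20000 nM, again a limit. Compound 2, with the structure `Cc1ccc(-c2cn(C[C@H]3c4c(ccc(O)c4C)[C@@H]4CC[C@@]5(C)C[C@]43CC5=O)nn2)cc1`, gives > 20000 nM, also a limit. For the measured compounds named here, the one step between measured compounds that differ in a single place, a step that the two limits leave unreadable from compound 1 to compound 3, cannot be read in size, since both ends sit at a limit; this is summed up by the limit of > 20000 nM in this assay, at which 3 of the 3 values shown sit, where every value so far rests.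

Compound 4, with the structure `Cc1ccc(-c2cn(C[C@H]3c4c(ccc(OS(=O)(=O)c5ccc(C)cc5)c4C)[C@@H]4CC[C@@]5(C)C[C@]43CC5=O)nn2)cc1`, is not yet measured. It differs from compound 3 as follows: methyl in place of fluoro on an aromatic carbon. Going by the values given here, no measured step shows how this change moves potency, and the nearby compounds give only limits, so the expected step that the limit leaves unreadable from compound 3 to compound 4 from compound 3 to compound 4 cannot be anchored in any read direction. Compound 4 is therefore expected to give about 30000 nM, within a range from 8000 nM to 150000 nM, most likely reported once more as a limit.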

Compound 4, half-maximal inhibitory concentration: > 20000 nM
Compound 4 ended at the assay's limit; the forecaster's own chance of this, stated with the estimate: 85%; the middle value does not contradict the limit.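

No new step can be read between compound 4 and compound 1, compound 2 or compound 3, because both ends of each comparison are limits and not numbers: the limit of > 20000 nM in this assay, at which 4 of the 4 values shown sit. The compounds shown leave open whether swapping methyl, fluoro or bromo, or adding the (4-methylphenyl)sulfonyl group, changes potency at all.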